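This account rests on a few compounds, and the source may have more. Where it says the series, first, only, none or still open, it means among the compounds named here.

Compound 1 `CNc1nc(SCc2nc3ccccc3[nH]2)nc(-c2ccccc2)c1C#N`: 19.2 nM
Compound 2 `CN1CCN(c2nc(SCc3nc4ccccc4[nH]3)nc(-c3ccccc3)c2C#N)CC1`: 6.75 nM

Going by the values given here, in a functional assay on U-937 cells (Homo sapiens) for cytotoxicity, read by MTT assay, with a stated time of 3 days (a lower number here means a stronger inhibitor, a higher number a weaker inhibitor), compound 2 gives 6.75 nM, the lower of the two numbers so far. Compound 3 `Cc1ccc(S(=O)(=O)N2CCN(c3nc(SCc4nc5ccccc5[nH]4)nc(-c4ccccc4)c3C#N)CC2)cc1` differs from it by (4-methylphenyl)sulfonyl in place of methyl on an amine nitrogen in a ring, with (4-methylphenyl)sulfonyl in place of methyl on an amine nitrogen in a ring. Among the compounds with values here, only one measured step bears on this: a 2.8-fold lower number from compound 1 to compound 2 (0.45 log units; beyond the scatter), which was modest and brought in the ring that now changes. Within the data shown here, the new group is far larger than methyl and has no measured precedent, so the direction is uncertain. In this assay a modest move toward a higher number is expected, an estimated 1.8-fold higher number from compound 2 to compound 3 (0.25 log units; within the scatter). The estimate for compound 3 is 12 nM, within an expected range of 3 nM to 50 nM.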

Compound 3, half-maximal inhibitory concentration: 4.1 nM
Compound 3: middle estimate off by 2.9-fold (0.47 log units), on the high side; the range from low to high includes it.
By their numbers in this assay, from the lowest: compounds 3 and 2 (each within the scatter of the next); then compound 1.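

In this assay, the amine nitrogen in the ring accepts (4-methylphenyl)sulfonyl, with its aromatic ring, in place of methyl with no real shift: a 1.6-fold lower number from compound 2 to compound 3 (0.22 log units; within the scatter). At this position, then, a much larger group with two added hydrogen-bond acceptors does not cost activity in these cells. No measurement here explains this result.

Still open, as far as these compounds go, is whether a methylsulfonyl group, an acetyl group or a bare hydrogen on that nitrogen would give a similar number. The sulfonyl and the 4-methylphenyl part also remain unseparated.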